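Bicyclic versus monocyclic thioether in a urea series

The source may hold more compounds than are shown below. What is called first, only, known or untested is meant among the compounds shown, and "the series" means these compounds.

Compound 1 `CCCCCCN(CCCCCSc1nc2ccccc2s1)C(=O)Nc1ccc(F)cc1F`: 2730 nM
Compound 2 `CCCCCCN(CCCCCSc1nc2ccc[nH]c-2n1)C(=O)Nc1ccc(F)cc1F`: 5470 nM
Compound 3 `CCCCCCCN(CCCCCSc1nc(O)c2ccccc2n1)C(=O)Nc1ccc(F)cc1F`: 11000 nM

In an assay on cells (Macrophage) for inhibition of sterol O-acyltransferase 1 (Mus musculus) (on this read-out lower numbers stand for stronger inhibition and higher numbers for weaker inhibition), compound 3 gives the highest of the three numbers. Its nearest neighbour on this read-out is compound 2, and the gap between them lies within the scatter; the gap to compound 1, whose number is lower, lies beyond it. Compound 4 `CCCCCCCN(CCCCCSc1ncccn1)C(=O)Nc1ccc(F)cc1F` differs from compound 3 in one place: pyrimidin-2-yl in place of 4-hydroxyquinazolin-2-yl on a sulfur. Going by the values given here, the only measured step at this position, a 2.0-fold higher number from compound 1 to compound 2 (0.30 log units; within the scatter), swapped one bicyclic group for another and stayed within the scatter. Among the compounds with values here, no measured step removes a fused ring or a hydroxy group here, and compounds 1 and 3 differ in the chain as well, so their gap cannot be read as a single change. On this basis the change is expected to move this assay little, with a slight lean towards a lower number because the bulkier group of compound 3 sits at 11000 nM while the other bicycles sit lower. Compound 4 is therefore estimated at 8000 nM, within 3000 nM to 25000 nM, a step of a 1.4-fold lower number from compound 3 to compound 4 (0.14 log units; within the scatter) that is expected to remain within the scatter.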

Compound 4, half-maximal inhibitory concentration: 4370 nM
Beside the measured number, compound 4's estimate is 1.8-fold (0.26 log units) above it, within the range that was stated.
By their numbers in this assay, from the lowest: compounds 1, 4, 2 and 3 (each within the scatter of the next, the first and the last beyond it).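

In this assay, going by these compounds alone, the exchange on the sulfur gives a 2.5-fold lower number from compound 3 to compound 4 (0.40 log units; beyond the scatter), the first step at this position to lie beyond the scatter, whereas a 2.0-fold higher number from compound 1 to compound 2 (0.30 log units; within the scatter), a swap of one bicyclic group for another, stayed within it. The group on the sulfur therefore matters to this read-out, and in this pair, going from 11 heavy atoms to 6, with one six-membered aromatic ring and the hydrogen-bond donor gone, lowers the number rather than raising it, so the second ring and the hydroxy group together bring no gain here. Nothing available here accounts for the size or direction of this step.

The exchange removes the fused ring and the hydroxy group at once, so the compounds shown leave open which of the two carries the step; quinazolin-2-yl and 4-hydroxypyrimidin-2-yl on the same sulfur would separate them. Also open, on these data alone, is whether the same exchange would give a step of similar size on the shorter chain of compound 1 and compound 2, and how a single ring with fewer ring nitrogens, such as pyridin-2-yl, would compare with pyrimidin-2-yl.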